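This account rests on a few compounds, and the source may have more. Where it says the series, first, only, none or still open, it means among the compounds named here.

Of the compounds shown here, two that share one core have been tested in a functional assay on MCF7 cells (Homo sapiens) for inhibition, read by MTT assay, with a stated time of 72 h; on this read-out higher numbers stand for weaker inhibition and lower numbers for stronger inhibition. Compound 1 `O=C1Nc2c(Br)cc(Br)cc2/C1=N/NC(=S)N1CCN(c2ccccc2)CC1` gives 11600 nM in this assay. Compound 2 `COc1ccc(N2CCN(C(=S)N/N=C3\C(=O)Nc4ccc(Cl)cc43)CC2)cc1` gives 13800 nM in this assay, the higher of the two numbers, although compound 1 sits within the scatter of it, so no order between the two can be read from these figures. Compound 3 `O=C1Nc2ccc(Cl)cc2/C1=N/NC(=S)N1CCN(c2ccc(Cl)c(Cl)c2)CC1` has not yet been measured. It differs from compound 2 in one place: 3,4-dichlorophenyl in place of 4-methoxyphenyl on an amine nitrogen in a ring. No step between measured compounds that carry this same change is shown, and the two values already known lie close to each other. On that basis compound 3 is expected to land near compound 2, with an expected step of a 1.4-fold lower number from compound 2 to compound 3 (0.14 log units; within the scatter), which would stay within the scatter rather than beyond it. The estimate for compound 3 in this assay is 10000 nM, with a range from 3500 nM to 30000 nM.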

Compound 3, half-maximal inhibitory concentration: 10800 nM
Compound 3: middle estimate off by 1.1-fold (0.03 log units), on the low side; the measured number falls inside the stated range.
By their numbers in this assay, from the lowest: compounds 3, 1 and 2 (each within the scatter of the next).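

In this assay, going by these compounds alone, the exchange of 4-methoxyphenyl for 3,4-dichlorophenyl on the amine nitrogen in a ring comes to a 1.3-fold lower number from compound 2 to compound 3 (0.11 log units; within the scatter), and this is the first step that isolates the group at this position, since compound 1 and compound 2 differ in more than one place. It shows that, on the chlorine-bearing core shared by compound 2 and compound 3, two aromatic carbon rings with different substituents give numbers that cannot be told apart, even though the group that leaves carries a hydrogen-bond acceptor and the group that enters carries none. No independent measurement bears on this result.

From the compounds shown here alone, whether a group of another kind on this ring nitrogen, such as a phenyl ring bearing a carboxylic acid or an amine, or a longer alkyl chain in place of the aromatic ring, would move the number beyond the scatter stays open. Going by these compounds, it is also open whether the same exchange would read the same way on the dibromo-substituted core of compound 1.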